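The source may report more compounds than this note shows. Statements on the series, on what has been measured and on what is new or still open speak of the compounds shown alone.

In a functional assay on MCF7 cells (Homo sapiens) for inhibition, read by sulforhodamine B assay (on this read-out higher numbers stand for weaker inhibition of growth and lower numbers for stronger inhibition of growth), compound 3 `Clc1cccc(-c2ccc(-c3ccc(-c4nc5ccccc5[nH]4)cc3)cc2)c1` gives 36300 nM. That places it level with compound 2 `CN(C)c1ccc(-c2ccc(-c3ccc(-c4nc5ccccc5[nH]4)cc3)cc2)cc1`, which gives 41200 nM, and well away from compound 1 `Cc1ccc2[nH]c(-c3ccc(-c4ccc(-c5cccc(Cl)c5)cc4)cc3)nc2c1`, which gives 1210 nM.

Compound 4 `Oc1cccc2[nH]c(-c3ccc(-c4ccc(-c5cccc(Cl)c5)cc4)cc3)nc12` is built from compound 3 by one small edit: hydroxy in place of hydrogen on an aromatic carbon. The carbon belongs to a six-membered aromatic ring of carbon only, part of a fused or bridged system of two rings.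

Two measured steps can be weighed here. The swap at the far end of the molecule gives a 1.1-fold lower number from compound 2 to compound 3 (0.05 log units; within the scatter), so it offers little guidance for this edit. For the measured compounds named here, the closer comparison is a 30-fold higher number from compound 1 to compound 3 (1.48 log units; beyond the scatter), where the only change is hydrogen in place of methyl on an aromatic carbon. Read backwards, this step suggests that a small group on the fused system can lower the number considerably. Going by the values given here, still, methyl is not hydroxy, and no measured compound here carries a hydroxy group, so this is a single, loose precedent.

In this assay, the expected change is therefore in the same direction but smaller, namely a 3.6-fold lower number from compound 3 to compound 4 (0.56 log units; beyond the scatter). For compound 4 the estimated value is 10000 nM, with an expected range from 2000 nM to 45000 nM.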

Compound 4, concentration for 50% growth inhibition: 3420 nM
Estimate against measurement, compound 4: 2.9-fold (0.47 log units) above; the range from low to high includes it.
By their numbers in this assay, from the lowest: compound 1; then compound 4; then compounds 3 and 2 (each within the scatter of the next).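

In this assay, the step of an 11-fold lower number from compound 3 to compound 4 (1.03 log units; beyond the scatter) shows that a hydroxy group alone, placed on an aromatic carbon of the six-membered aromatic ring of carbon only, moves the number well beyond the usual scatter. Before this result, the only measured change on that fused system was the loss of a methyl group, a 30-fold higher number from compound 1 to compound 3 (1.48 log units; beyond the scatter), so it was unclear whether a group other than methyl could also give a number lower than that of compound 3; compound 4 now shows that one can. The data shown contain nothing that explains why adding the hydroxy group has this effect.

From the compounds shown here alone, whether the hydrogen of the hydroxy group matters or the oxygen alone is enough remains open, and a methoxy group on the same carbon would help to separate the two, while an amine or a carboxylic acid there would show how far the result extends to other groups. The compounds shown also carry the hydroxy group on only one carbon of this ring, so it remains unknown whether the same edit would lower the number to a similar extent on any other carbon of the ring.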